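The source may hold more compounds than are shown below. What is called first, only, known or untested is meant among the compounds shown, and "the series" means these compounds.

Going by the values given here, compound 1 `Cc1cccc(N(C)CCCN2CCN(c3ccccc3)CC2)c1` is one of two compounds measured in an assay on HEK293 cells for displacement of a labelled ligand from 5-hydroxytryptamine receptor 7 (Homo sapiens), read by scintillation counting, with a stated time of 30 min; on this read-out higher numbers stand for weaker inhibition and lower numbers for stronger inhibition. In this assay compound 1 gives 84.8 nM, the higher of the two numbers. Among the compounds with values here, the other measured compound, compound 2 `CN(CCCN1CCN(c2cccc3ccccc23)CC1)c1cccc(O)c1`, gives 2.9 nM in this assay; it differs from compound 1 in more than one place, so its lower number tells nothing on its own about any single change, only that a compound of the same general shape reaches a far stronger result.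

Compound 3 `CN(CCCN1CCN(c2ccccc2)CC1)c1cccc(NS(C)(=O)=O)c1` differs from compound 1 in one place: methanesulfonamido in place of methyl on an aromatic carbon. Within the data shown here, no pair of measured compounds shows this change, so its effect must be guessed. The much stronger result of compound 2 at 2.9 nM, where a hydrogen-bond donor also sits on the corresponding ring, gives a loose hint that a donor and acceptors in this place need not be harmful, but the second difference in compound 2 leaves that hint weak. The account therefore expects a modest step toward a lower number for compound 3, a 2.1-fold lower number from compound 1 to compound 3 (0.33 log units; beyond the scatter), with the chance of no step beyond the scatter kept open. The estimate for compound 3 is 40 nM, within a range from 10 nM to 150 nM.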

Compound 3, inhibition constant: 39.6 nM
Compound 3: the middle estimate sits 1.0-fold (0.00 log units) above what was measured, and the stated range covers the measured number.
By their numbers in this assay, from the lowest: compound 2; then compound 3; then compound 1.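

Going by these compounds alone, the replacement of methyl by methanesulfonamido, on an aromatic carbon meta to a large group, gives a 2.1-fold lower number from compound 1 to compound 3 (0.33 log units; beyond the scatter) in this assay, the first reading of a single change at this place. It shows that on the core of compound 1 this position tolerates a far larger substituent, with 5 heavy atoms entering where 1 leaves, and that the added hydrogen-bond donor and hydrogen-bond acceptors come with a modest move toward stronger inhibition rather than a loss. Nothing measured on the compounds here explains this step, and with a single pair it stands as one observation about this change, not as a pattern.

On these data alone, the step cannot be divided among the size of the group, its donor and its acceptors, so it remains open whether an acetamido, amino or methoxy group at the same place would give a similar number, or whether a methanesulfonamido group with a methyl on its nitrogen would keep the step. As far as these compounds go, it also remains open whether the same replacement would move the number in the same direction on a core other than that of compound 1.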